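A few compounds are considered here, and "the series" means these few. Any claim that something is new, unique, unknown or untested is made for them only; others in the source may bear on it.

Two closely related compounds from this study have been tested in an ADME assay on RAW264.7 cells (Mus musculus) for cytotoxicity, read by luminescence and CellTiter-Glo, with a stated time of 18 h, tested at 0.1 uM; a lower number here means a stronger effect, a higher number a weaker effect of the compound at the concentration tested. Compound 1, with the structure `C=C1CC[C@H]2C(C)(C)CCC[C@]2(C)[C@H]1C/C=C1/C(=O)OC[C@H]1O`, is one of them; in this assay compound 1 gives 103%. Compound 2, with the structure `C=C1CC[C@H]2C(C)(C)CCC[C@]2(C)[C@H]1/C=C/C1=CCOC1=O`, is the other; in this assay compound 2 gives 104%. These two numbers lie within the usual scatter of each other, so neither compound can be said to act more strongly than the other; both leave the cells essentially as viable as untreated cells at the tested concentration.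

Compound 3, with the structure `C=C1CC[C@H]2C(C)(C)CCC[C@]2(C)[C@H]1C/C=C1\C(=O)OC[C@H]1O`, has not yet been tested. Compared with compound 1, (the two compounds have the same atoms and bonds and differ only in configuration as drawn: 1 of 5 stereo elements differ; a double bond is drawn E in compound 1 and Z in compound 3). In plain terms, every atom and bond is kept, and only the geometry drawn at one double bond is turned around.

Among the compounds with values here, no measured pair in this set differs in just one place, so there is no directly comparable step to lean on. Given that compound 1 and compound 2 both sit at full viability, the expectation for the change from compound 1 to compound 3 is a step of a number 1 percentage points lower from compound 1 to compound 3 (within the scatter), that is, nothing beyond the scatter. On that basis compound 3 is expected to give about 102% in this assay, most likely between 90% and 112%.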

Compound 3, a percentage reported as activity, at one concentration (the size of the read-out at that concentration, not a potency): 100%
For compound 3 the middle estimate is 2 percentage points above the measured one; low and high end bracket the measured number.
By their numbers in this assay, from the lowest: compounds 3, 1 and 2 (each within the scatter of the next).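

Within the data shown here, compounds 1 and 3 form the first pair here that can be compared directly, and turning the double bond from E to Z gives a step of a number 3 percentage points lower from compound 1 to compound 3 (within the scatter) in this assay. This shows that, at the single concentration tested, the drawn geometry at this double bond makes no difference that can be told from ordinary repeat-to-repeat variation, so either geometry leaves the cells as viable as untreated cells. The pair is a clean test of that one feature, because nothing else separates the two structures: the fact that compounds 1 and 3 differ only in the configuration as drawn

Since this is a reading at one concentration and not a potency, the compounds shown leave open whether the two geometries would still match at a concentration where cell viability starts to fall. They also leave open whether a different group on the shared core, such as an amine or a carboxylic acid, would shift the reading in this assay at all.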